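Trimming One Methoxy Group from Compound 1

The source may hold more compounds than are shown below. What is called first, only, known or untested is meant among the compounds shown, and "the series" means these compounds.

Compound 1 `COc1cc(/C=N/N(C)c2nc3ccccc3s2)cc(OC)c1O`: 110%
Compound 2 `COc1cc(/C=N/N(C)c2nc3ccccc3s2)cc(OC)c1OC`: 7%

In a functional assay on cells (Mus musculus) for cytotoxicity, read by MTT assay, with a stated time of 24 h, tested at 10 uM (on this read-out lower numbers stand for a weaker effect and higher numbers for a stronger effect at the one concentration tested), compound 1 gives 110%, the highest of the two numbers, while compound 2 gives 7%. Going by the values given here, the one measured step, a number 103 percentage points lower from compound 1 to compound 2 (beyond the scatter), concerns a different change from the one leading to compound 3 `COc1cc(/C=N/N(C)c2nc3ccccc3s2)ccc1O`, in which (hydrogen in place of methoxy on an aromatic carbon). Among the compounds with values here, no measured step bears directly on this change; compound 3 does keep the free hydroxy group that compound 2 lacks. Because compound 1 gives 110%, only a modest loss is expected; the expected step is a number 25 percentage points lower from compound 1 to compound 3 (beyond the scatter). Compound 3 is estimated at 85%, within 40% to 115%.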

Compound 3, a percentage reported as activity, at one concentration (the size of the read-out at that concentration, not a potency): 96%
Compound 3: the middle estimate sits 11 percentage points below what was measured; measured number inside the range.
By their numbers in this assay, from the lowest: compound 2; then compound 3; then compound 1.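

Replacing the methoxy group ortho to a hydroxy group with hydrogen costs only a modest amount: this assay shows a number 14 percentage points lower from compound 1 to compound 3 (beyond the scatter). This position therefore tolerates losing the methoxy group far better than the hydroxy oxygen tolerated gaining a methyl, which gave a number 103 percentage points lower from compound 1 to compound 2 (beyond the scatter). No available evidence explains either step.

The compounds shown leave open whether an amine or an ethoxy group on this aromatic carbon would hold the read-out as hydrogen does. They also leave open how a carboxylic acid in place of the hydroxy group would fare.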